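This account rests on a few compounds, and the source may have more. Where it says the series, first, only, none or still open, it means among the compounds named here.

Measured in a functional assay on DU-145 cells (Homo sapiens) for cytotoxicity, read by MTT assay, with a stated time of 48 h; on this read-out lower numbers stand for stronger inhibition and higher numbers for weaker inhibition:
- compound 1 `CCOC(=O)c1c(-c2c(Cl)c3ccccc3oc2=O)nn(-c2cccc(C)c2)c1C(=O)OCC`: 32000 nM
- compound 2 `CCOC(=O)c1c(-c2c(Cl)c3ccccc3oc2=O)nn(-c2cccc(Cl)c2)c1C(=O)OCC`: 24000 nM
- compound 3 `CCOC(=O)c1c(-c2cc3ccccc3oc2=O)nn(-c2cccc(C)c2)c1C(=O)OCC`: 47000 nM

All three numbers sit close together. Compound 3 does not separate from compound 1, the step of a 1.5-fold higher number from compound 1 to compound 3 (0.17 log units; within the scatter), and its gap to compound 2 is also within the scatter, so no ranking among the three is supported.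

Compound 4 `CCOC(=O)c1c(-c2cc3ccccc3oc2=O)nn(-c2cccc(Cl)c2)c1C(=O)OCC` carries the change (chloro in place of methyl on an aromatic carbon). The same change has been measured once, on the chloro-bearing core, as a 1.3-fold lower number from compound 1 to compound 2 (0.12 log units; within the scatter), which is within the scatter. Carried over to compound 3, the step to compound 4 is therefore expected to be small, a 1.3-fold lower number from compound 3 to compound 4 (0.12 log units; within the scatter), with no direction claimed beyond the scatter. Compound 4 is estimated at 36000 nM, within 18000 nM to 72000 nM.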

Compound 4, half-maximal inhibitory concentration: 35000 nM
Compound 4: the middle estimate sits 1.0-fold (0.01 log units) above what was measured; measured number inside the range.
By their numbers in this assay, from the lowest: compounds 2, 1, 4 and 3 (each within the scatter of the next).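

In this assay the swap of 3-methylphenyl to 3-chlorophenyl now has a second reading on the core without the aromatic chloro (a 1.3-fold lower number from compound 3 to compound 4 (0.13 log units; within the scatter)), and it agrees with the first: the same change on two cores in this assay, a 1.3-fold lower number (0.12 log units; within the scatter) from compound 1 to compound 2 and a 1.3-fold lower number (0.13 log units; within the scatter) from compound 3 to compound 4, 1.0-fold (0.00 log units) apart, within the scatter of two such steps. Hydrogen in place of that chloro also has a second reading, now with 3-chlorophenyl in place (a 1.5-fold higher number from compound 2 to compound 4 (0.16 log units; within the scatter)), and again the two agree: the same change on two cores in this assay, a 1.5-fold higher number (0.17 log units; within the scatter) from compound 1 to compound 3 and a 1.5-fold higher number (0.16 log units; within the scatter) from compound 2 to compound 4, 1.0-fold (0.00 log units) apart, within the scatter of two such steps. Neither change therefore moves the number beyond the scatter in either setting.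

As far as these compounds go, whether an amine or a carboxylic acid on this aromatic carbon would separate from methyl and chloro stays open.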